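Changing the Aryl Group on the Amino Nitrogen

The compounds below may be only part of what the source reports. "The series", "measured", "known", "first", "only" and "open" are said of these compounds alone.

Two measured compounds share one core and differ only in the aryl group carried on a nitrogen attached to an aromatic ring. Compound 1 `FC(F)(F)c1ccc(CSc2nc(Nc3ccccc3Cl)c3ccccc3n2)cc1` carries a 2-chlorophenyl there. In a functional assay on MGC-803 cells (Homo sapiens) for cytotoxicity, read by MTT assay, with a stated time of 72 h (a higher number here means a weaker inhibitor, a lower number a stronger inhibitor), compound 1 gives only a limit, > 50000 nM, so its true value is not known beyond that boundary. Compound 2 `O=[N+]([O-])c1ccc(Nc2nc(SCc3ccc(C(F)(F)F)cc3)nc3ccccc23)cc1` carries a 4-nitrophenyl instead, and in this assay compound 2 gives 8170 nM. Going by the values given here, the single measured step, an at least 6.1-fold lower number from compound 1 to compound 2 (0.78 log units; beyond the scatter), shows that replacing this aryl group can lower the number markedly, though because compound 1 sits at the limit of > 50000 nM in this assay, at which 1 of the 2 values shown sits, only a lower bound of that step is known.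

Compound 3 `Fc1ccc(Nc2nc(SCc3ccc(C(F)(F)F)cc3)nc3ccccc23)cc1Cl` is not yet measured; it differs from compound 1 by 3-chloro-4-fluorophenyl in place of 2-chlorophenyl on a nitrogen on an aromatic ring. This is a different replacement from the one measured, so the step from compound 1 to compound 2 bears on it only as a sign that this position tolerates change. The expectation is that compound 3 moves in the same direction, by an at least 2.5-fold lower number from compound 1 to compound 3 (0.39 log units; beyond the scatter), a smaller shift than the measured one. The estimated value for compound 3 in this assay is 20000 nM, with a likely range from 5000 nM to 60000 nM.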

Compound 3, half-maximal inhibitory concentration: > 50000 nM
Compound 3: no number, only a limit; the forecaster's own chance of this, stated with the estimate: 40%; at least 2.5-fold (0.39 log units) between middle value and limit.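

Compound 3 shows that moving away from the 2-chlorophenyl group does not by itself bring the number down in this assay: with 3-chloro-4-fluorophenyl on the nitrogen, the reading > 50000 nM is a limit and not a number. The comparison with the 4-nitrophenyl group gives an at least 6.1-fold higher number from compound 2 to compound 3 (0.78 log units; beyond the scatter) and so, among the three aryl groups shown, the lower number goes with 4-nitrophenyl alone, which makes this position sensitive to which aryl group it carries rather than open to any change. The step from compound 1 to compound 3 cannot be read, because both compounds stop at the same boundary: the limit of > 50000 nM in this assay, at which 2 of the 3 values shown sit.

With compound 2 the only one of the three that gives a true number, the compounds shown offer no trend across aryl groups, only a contrast between one measured compound and two limits. Going by these compounds, it stays open whether a phenyl ring carrying a nitrile, an amine or a carboxylic acid in place of the nitro group would keep, lower or lose the number seen for compound 2.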